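A Bulkier Ester Replaces Methoxy on a Weak Inhibitor

The source may hold more compounds than are shown below. What is called first, only, known or untested is meant among the compounds shown, and "the series" means these compounds.

Of the compounds shown here, three built on one shared core have been tested in an assay on isolated protein for inhibition of long-chain fatty acid transport protein 1 (Mus musculus); a higher number here means a weaker inhibitor, a lower number a stronger inhibitor. Compound 1 `CCn1c(CNc2ccccc2)nnc1SCC(=O)Nc1ccc(OC)cc1` carries a methoxy on an aromatic carbon. In this assay compound 1 gives > 10000 nM, which is a limit of the assay rather than a number (the limit of > 10000 nM in this assay, at which 1 of the 3 values shown sits). Compound 2 `CCn1c(CNc2ccccc2)nnc1SCc1nc2cc(Cl)ccc2o1`, whose arm on the sulfur side is built differently, gives 2300 nM in this assay. Compound 3 `CCC(=O)c1ccc2nc(CSc3nnc(CNc4ccccc4)n3CC)oc2c1`, with yet another arm on that side, gives 1200 nM. Neither is a single-change neighbour of compound 1, so their values show only that some arms reach measurable inhibition while the arm of compound 1 does not.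

Compound 4 `CCn1c(CNc2ccccc2)nnc1SCC(=O)Nc1ccc(C(=O)OC(C)(C)C)cc1` differs from compound 1 in one place: tert-butoxycarbonyl in place of methoxy on an aromatic carbon. Going by the values given here, no measured step of this kind exists among the three compounds, so any expectation rests on the weak starting point alone. Since compound 1 sits at a limit, the size of the step cannot be read from a number. The expected step is an at least 1.1-fold lower number from compound 1 to compound 4 (0.04 log units; that floor lies within the scatter), a modest gain that may not exceed the usual scatter. Compound 4 is estimated at 9000 nM, within a range from 2500 nM to 30000 nM, and a result that is again only a limit is quite possible.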

Compound 4, half-maximal inhibitory concentration: > 10000 nM
Compound 4: only a limit was reported; the forecaster's own chance of this, stated with the estimate: 55%; at least 1.1-fold (0.04 log units) between middle value and limit.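

In this assay, compound 1 and compound 4 both stand at a limit of the assay rather than at a number, and the step between them cannot be read: the limit of > 10000 nM in this assay, at which 2 of the 4 values shown sit. The compounds shown leave open how strongly either compound inhibits, and whether tert-butoxycarbonyl in place of methoxy changes inhibition at all.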